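Extending the sulfone chain: from compound 2 to compound 4

The source may hold more compounds than are shown below. What is called first, only, known or untested is meant among the compounds shown, and "the series" means these compounds.

Of the compounds shown here, three share a core and have been measured in an ADME assay on a cell-free system (plasma, Mus musculus); a higher number here means a larger unbound share of the compound, a lower number a smaller unbound share. Compound 1 `COCCN(C)S(=O)(=O)c1ccc(C)c(C#Cc2cc(Cl)ccc2OCC(=O)O)c1` gives 0.007. Compound 3 `Cc1ccc(S(=O)(=O)NC(C)C)cc1C#Cc1cc(Cl)ccc1OCC(=O)O` gives 0.01, and the step of a 1.4-fold higher number from compound 1 to compound 3 (0.15 log units; within the scatter). Compound 2 `CS(=O)(=O)c1ccc(F)c(C#Cc2cc(Cl)ccc2OCC(=O)O)c1` gives 0.054, the highest of the three numbers, with compound 3 and compound 1 both lying beyond the scatter below it.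

Compound 4 `CCCS(=O)(=O)c1ccc(F)c(C#Cc2cc(Cl)ccc2OCC(=O)O)c1` has not yet been measured. It differs from compound 2 as follows: ethyl in place of hydrogen on a saturated chain carbon bound to a sulfonyl sulfur. Within the data shown here, the only measured step, from compound 1 to compound 3, concerns the nitrogen substituent on a sulfonyl sulfur rather than a saturated chain carbon, and it lies within the scatter, so no measured step bears directly on this change. The account therefore rests on the value of compound 2 alone. A modest lowering of the unbound fraction is expected for compound 4, with the step estimated as a 1.8-fold lower number from compound 2 to compound 4 (0.26 log units; within the scatter). On that basis the unbound fraction of compound 4 is estimated at 0.03, within a range from 0.012 to 0.07.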

Compound 4, unbound fraction: 0.007
Beside the measured number, compound 4's estimate is 4.3-fold (0.63 log units) above it; the measured number lies below the stated range.
By their numbers in this assay, from the lowest: compounds 1, 4 and 3 (each within the scatter of the next); then compound 2.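

In this assay, the chain on the sulfonyl sulfur proves to be a sensitive place: going from methylsulfonyl to propylsulfonyl gives a 7.7-fold lower number from compound 2 to compound 4 (0.89 log units; beyond the scatter). The earlier step changed only the nitrogen substituent on a sulfonyl sulfur and, at a 1.4-fold higher number from compound 1 to compound 3 (0.15 log units; within the scatter), did not leave the scatter, so this is the only change shown around the sulfonyl group that clearly lowers the unbound fraction. No measured evidence accounts for the size of this step.

Going by these compounds, whether the unbound fraction keeps falling with a longer chain such as butyl, and where an ethyl chain on the sulfonyl sulfur would stand, remains open. So does whether a hydroxyl group or an amine at the end of the propyl chain would restore the value of compound 2.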